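This account rests on a few compounds, and the source may have more. Where it says the series, first, only, none or still open, it means among the compounds named here.

In an ADME assay on L02 cells (Homo sapiens) for inhibition, read by CCK-8 assay, with a stated time of 48 h (a lower number here means a stronger inhibitor of growth, a higher number a weaker inhibitor of growth), compound 1 `Cc1ccccc1Nc1nc(NC2CC2)ncc1Cl` gives > 100000 nM, which is a limit of the assay and not a number. Compound 2 `Cc1ccc(Nc2ncc(Cl)c(Nc3ccccc3C)n2)cc1` gives > 100000 nM, also a limit. Compound 2 therefore stands at the limit of > 100000 nM in this assay, at which 2 of the 3 values shown sit. For the measured compounds named here, compound 3 `Cc1ccccc1Nc1nc(Nc2cc(Cl)ccn2)ncc1Cl` gives 41500 nM, the only true number so far.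

The next compound to be tested is compound 4 `Cc1ccccc1Nc1nc(Nc2ccc(N3CCCN(C)CC3)cc2)ncc1Cl`, which differs from compound 2 by one change: 4-methyl-1,4-diazepan-1-yl in place of methyl on an aromatic carbon. In words, 4-methyl-1,4-diazepan-1-yl stands in place of methyl on an aromatic carbon.

Going by the values given here, no measured step makes this exact change, but three steps alter the same group on a nitrogen on an aromatic ring. Putting 4-methylphenyl in place of cyclopropyl gives a step that the two limits leave unreadable from compound 1 to compound 2. Putting 4-chloropyridin-2-yl in place of cyclopropyl gives an at least 2.4-fold lower number from compound 1 to compound 3 (0.38 log units; beyond the scatter), and putting it in place of 4-methylphenyl gives an at least 2.4-fold lower number from compound 2 to compound 3 (0.38 log units; beyond the scatter). Going by compound 3 with an at least 2.4-fold lower number from compound 2 to compound 3 (0.38 log units; beyond the scatter), the one change seen to move the number off the limit, a modest step to a lower number, meaning stronger growth inhibition, seems likely, though compound 4 could stay at the limit.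

The estimate amounts to an at least 2.8-fold lower number from compound 2 to compound 4 (0.45 log units; beyond the scatter), an expected shift of uncertain size. For compound 4 the expected value is 35000 nM, with an estimated range from 9000 nM to 100000 nM.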

Compound 4, concentration for 50% growth inhibition: 1240 nM
Compound 4: the middle estimate sits 28-fold (1.45 log units) above what was measured; measured number outside the range, below it.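

In this assay, putting 4-methyl-1,4-diazepan-1-yl in place of methyl on the aromatic carbon gives an at least 80-fold lower number from compound 2 to compound 4 (1.90 log units; beyond the scatter), a large step. Until now, the only readable move off the limit came from replacing the whole group on the nitrogen, whereas here the six-membered aromatic ring stays and only the group it carries changes, which alone is enough to give a true number and much stronger growth inhibition. Compound 2 has only a limit and not a number, so the real size of this step is not fixed and it could be larger still: the limit of > 100000 nM in this assay, at which 2 of the 4 values shown sit.

The entering group brings a seven-membered non-aromatic ring and its nitrogens in a single change, and the compounds shown do not separate what each of these parts contributes. On these data alone, it also remains open whether a simple dimethylamino group, a piperazine ring or the same seven-membered ring without its methyl would give a similar number at this place, or whether the step depends on this exact group.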